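The compounds below may be only part of what the source reports. "The series", "measured", "known", "first", "only" and "open" are said of these compounds alone.

Measured compounds:
- compound 1, `CC[C@H](CCn1cncn1)c1ccc(F)cc1`: 103 ug/mL
- compound 2, `CC[C@H](CCn1cncn1)c1ccc(Cl)cc1`: 50.6 ug/mL

Going by the values given here, in an ADME assay on HEp-2 cells (Homo sapiens) for cytotoxicity, read by MTT assay, with a stated time of 3 days (on this read-out lower numbers stand for higher toxicity in this test and higher numbers for lower toxicity in this test), compound 1 stands at 103 ug/mL, the higher of the two numbers so far. Among the compounds with values here, the only measured step in the set is a 2.0-fold lower number from compound 1 to compound 2 (0.31 log units; beyond the scatter), which comes from chloro in place of fluoro on an aromatic carbon; it is a modest step and concerns the ring substituent, not the chain.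

Compound 3, `CCC[C@H](CCn1cncn1)c1ccc(F)cc1`, has not been measured. It differs from compound 1 by methyl in place of hydrogen on a saturated chain carbon, three bonds along the chain from an aromatic carbon. Within the data shown here, no measured step in this assay touches the saturated chain: the single step known changes the halogen on the ring, so nothing in the data speaks for or against a shift when the ethyl becomes a propyl. The step from compound 1 to compound 3 is therefore expected to lie within the scatter, with no direction that the data support.

Compound 3 is expected to give about 90 ug/mL in this assay, with a range from 40 ug/mL to 200 ug/mL. For compound 3 this estimate means a 1.1-fold lower number from compound 1 to compound 3 (0.06 log units; within the scatter), a step that is expected to stay inside the usual scatter.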

Compound 3, half-maximal cytotoxic concentration: 39.3 ug/mL
Estimate against measurement, compound 3: 2.3-fold (0.36 log units) above; the whole stated range lies above it.
By their numbers in this assay, from the lowest: compounds 3 and 2 (each within the scatter of the next); then compound 1.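

In this assay the saturated chain is not a silent position: methyl in place of hydrogen on a saturated chain carbon, three bonds along the chain from an aromatic carbon, gives a 2.6-fold lower number from compound 1 to compound 3 (0.42 log units; beyond the scatter). Until now only the ring halogen had been seen to move this number, and a 2.0-fold lower number from compound 1 to compound 2 (0.31 log units; beyond the scatter) runs the same way, so both single changes away from compound 1 point toward higher toxicity in this test. Nothing measured here bears on why the change from ethyl to propyl has this effect.

Still open, on these data alone, is whether a longer chain such as butyl continues the trend seen on going from ethyl to propyl, or whether the shift stops at propyl, and whether a hydroxyl or an amine on the same chain gives a step in the same direction. Also open, as far as these compounds go, is whether the propyl chain and the chloro, placed together on the core of compound 1, add up or overlap in this assay's read-out.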